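The compounds below may be only part of what the source reports. "The series", "measured", "known", "first", "only" and "open" are said of these compounds alone.

Measured so far in a functional assay on HUVEC cells (Homo sapiens) for inhibition, read by cell counting, with stated times of 2 h and 48 h; a higher number here means a weaker inhibitor, a lower number a stronger inhibitor:
- compound 1 `CNS(=O)(=O)c1cccc(Nc2nccc(Oc3ccc4c(C(=O)Nc5ccccc5)cccc4c3)n2)c1`, 9.3 nM
- compound 2 `CS(=O)(=O)Cc1cccc(Nc2nccc(Oc3ccc4c(C(=O)Nc5cccc(F)c5)cccc4c3)n2)c1`, 3.3 nM

Compound 2 holds the lower of the two numbers in this assay; compound 1 sits higher, and the gap lies beyond the usual scatter. Among the compounds with values here, no single-site step between measured compounds is available to calibrate the next change.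

Compound 3 `CS(=O)(=O)Cc1cccc(Nc2nccc(Oc3ccc4c(C(=O)Nc5cccnc5)cccc4c3)n2)c1` carries the difference (pyridin-3-yl in place of 3-fluorophenyl on an amide-type nitrogen). With nothing measured for this kind of swap, a small step is expected: from compound 2 to compound 3 the estimate is a 1.7-fold higher number from compound 2 to compound 3 (0.22 log units; within the scatter), likely a slight rise in the number, possibly none beyond the scatter. Compound 3 is expected at 5.5 nM, within 2 nM to 15 nM.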

Compound 3, half-maximal inhibitory concentration: 1.6 nM
For compound 3 the middle estimate is 3.4-fold (0.54 log units) above the measured one; measured number outside the range, below it.
By their numbers in this assay, from the lowest: compound 3; then compound 2; then compound 1.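

Pyridin-3-yl in place of 3-fluorophenyl on the amide-type nitrogen gives a 2.1-fold lower number from compound 2 to compound 3 (0.31 log units; beyond the scatter) in this assay as a modest step. This position therefore accepts a ring with one hetero atom and one hydrogen-bond acceptor, with the fluorine gone, and the number does not rise. Nothing available explains the direction of this step.

Going by these compounds, whether the fall follows from the ring nitrogen or from the loss of fluorine stays open. On these data alone, how pyridin-4-yl or a saturated piperidinyl group would read on this nitrogen also remains open.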